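Swapping an Ester-Bearing Arm for a Carbamoyl Group

The source may report more compounds than this note shows. Statements on the series, on what has been measured and on what is new or still open speak of the compounds shown alone.

Measured so far:
Compound 1, `C=C(CC)C(=O)c1ccc(OCC(=O)Nc2ccc(/C=C/C(=O)OCC)cc2)c(Cl)c1Cl`: 1700 nM
Compound 2, `C=C(CC)C(=O)c1ccc(OCC(=O)Nc2ccc3c(c2)C(O)N=NC3O)c(Cl)c1Cl`: 8500 nM

Both compounds share a core and were tested in a functional assay on CLL cells (Homo sapiens) for cytotoxicity, read by MTT assay, with a stated time of 48 h; a lower number here means that less compound is needed, a higher number that more compound is needed for the effect. Compound 1 gives the lowest of the two numbers; compound 2 gives a number that is higher by a margin beyond the usual scatter. Compound 3, `C=C(CC)C(=O)c1ccc(OCC(=O)Nc2ccc(C(N)=O)cc2)c(Cl)c1Cl`, has not yet been tested. It differs from compound 1 in one place: carbamoyl in place of 2-(ethoxycarbonyl)ethenyl on an aromatic carbon. Going by the values given here, no step between two measured compounds of this exact kind is available, so the expected size of the step is uncertain. Since cytotoxicity here has been seen across both measured compounds within a moderate span, compound 3 is expected to remain in the same broad region, with a small to moderate rise in the number, expressed as the step of a 1.8-fold higher number from compound 1 to compound 3 (0.25 log units; within the scatter). The estimate for compound 3 is 3000 nM, with a range from 1000 nM to 9000 nM.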

Compound 3, half-maximal effective concentration: 3700 nM
The estimate for compound 3 lay 1.2-fold (0.09 log units) below the measured number; the measured number falls inside the stated range.
By their numbers in this assay, from the lowest: compound 1; then compound 3; then compound 2.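

In this assay, this position on the aromatic ring, para to a large group, now has its first comparison of a single change: a 2.2-fold higher number from compound 1 to compound 3 (0.34 log units; beyond the scatter). The 2-(ethoxycarbonyl)ethenyl arm, with 7 heavy atoms, can therefore be replaced by carbamoyl, with 3 heavy atoms, at a modest cost in the number, and compound 3 still has a measurable effect on the cells. No supporting measurement is available to explain this step.

The change alters the size of the group, its double bonds and its hydrogen-bond donors and acceptors all at once, so the compounds shown cannot separate these features. Going by these compounds, how an amine, a carboxylic acid or a longer chain ending in carbamoyl would read in this same position remains open.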